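Nitro substitution on the ester of compound 2

A few compounds are considered here, and "the series" means these few. Any claim that something is new, unique, unknown or untested is made for them only; others in the source may bear on it.

Measured so far:
compound 1 `CC(=O)O[C@@H]1C=CC(=O)O[C@@H]1[C@@H](COC(=O)c1ccc(Cl)cc1)OC(C)=O` — 11000 nM
compound 2 `O=C1C=C[C@@H](OCc2ccccc2)[C@@H]([C@@H](COC(=O)/C=C/c2ccccc2)OCc2ccccc2)O1` — 9510 nM

Two compounds carry numbers in a functional assay on HeLa cells (Homo sapiens) for antiproliferative activity, read by MTT assay, with a stated time of 6 days (on this read-out lower numbers stand for stronger inhibition and higher numbers for weaker inhibition), so far. Compound 1 gives 11000 nM and compound 2 gives 9510 nM in this assay. Compound 2 has the lowest of the two numbers, but its nearest neighbour, compound 1, lies within the scatter of it, so no order between the two is claimed.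

Compound 3 `O=C1C=C[C@@H](OCc2ccccc2)[C@@H]([C@@H](COC(=O)/C=C/c2ccc([N+](=O)[O-])cc2)OCc2ccccc2)O1` has not been measured in this assay. Its difference from compound 2 is nitro in place of hydrogen on an aromatic carbon, para to a large group, so that the 2-phenylethenyl ester becomes a 2-(4-nitrophenyl)ethenyl ester. Within the data shown here, no step between measured compounds covers such a change, and nothing else in the set bears on it. For compound 3 the expected step is a 1.2-fold lower number from compound 2 to compound 3 (0.08 log units; within the scatter), nothing beyond the scatter in either direction. Compound 3 is estimated at 8000 nM in this assay, with a range from 3000 nM to 25000 nM.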

Compound 3, half-maximal inhibitory concentration: 2650 nM
Compound 3: middle estimate off by 3.0-fold (0.48 log units), on the high side; the measured number lies below the stated range.
By their numbers in this assay, from the lowest: compound 3; then compounds 2 and 1 (each within the scatter of the next).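

In this assay, the aromatic ring of the 2-phenylethenyl ester proves to be a place where one substitution moves the number beyond the scatter: nitro in place of hydrogen gives a 3.6-fold lower number from compound 2 to compound 3 (0.55 log units; beyond the scatter). Among these compounds, compound 1 and compound 2 could not show this, as they differ in more than one place and offered no step to read. Nothing measured here bears on the origin of this step.

On these data alone, whether the step belongs to nitro specifically remains open, since an amine, a carboxylic acid or a methoxy group at the same place on the ring could give a smaller, similar or larger step. Also open, as far as these compounds go, is whether phenyl to 4-nitrophenyl gives a comparable step in an ester on the core of compound 1, which would test the change away from the shared core of compound 2 and compound 3.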